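Chloro in Place of Nitro on a Shared Core

The compounds below may be only part of what the source reports. "The series", "measured", "known", "first", "only" and "open" are said of these compounds alone.

Compound 1 `CCn1c(/C=C2/C(=O)Nc3ccccc32)nc2ccccc21` in a functional assay on 4T1 cells (Homo sapiens) for cytotoxicity, read by MTT assay, with a stated time of 48 h (a higher number here means a weaker inhibitor, a lower number a stronger inhibitor), gives only a limit of the assay, > 50000 nM.
Compound 2 `CCn1c(/C=C2/C(=O)Nc3ccc(C)cc32)nc2ccccc21` in this assay gives 39400 nM.
Compound 3 `CCn1c(/C=C2/C(=O)Nc3ccc([N+](=O)[O-])cc32)nc2ccccc21` in this assay gives only a limit of the assay, > 50000 nM.

Compound 3 thus stands at the edge of what this assay can report, and compound 1 sits at the same edge, as the limit of > 50000 nM in this assay, at which 2 of the 3 values shown sit, records. Compound 4 `CCn1c(/C=C2/C(=O)Nc3ccc(Cl)cc32)nc2ccccc21` differs from compound 3 in a single place: chloro in place of nitro on an aromatic carbon. Within the data shown here, two measured steps touch compound 3. an at least 1.2-fold higher number from compound 2 to compound 3 (0.10 log units; that floor lies within the scatter), a step whose floor lies within the scatter. a step that the two limits leave unreadable from compound 1 to compound 3. Among the measured compounds shown here, neither step involves a chloro group, and no measured compound carries one, so the bearing on compound 4 is slight; the only actual number among the three belongs to compound 2. A weak inhibitor is therefore expected for compound 4 too, with an expected step of an at least 1.2-fold lower number from compound 3 to compound 4 (0.09 log units; that floor lies within the scatter). For compound 4 the estimate in this assay is 40000 nM, with a range from 15000 nM to 100000 nM, and a fair chance that the assay again reports only a limit.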

Compound 4, half-maximal inhibitory concentration: > 50000 nM
Compound 4 ended at the assay's limit; the forecaster's own chance of this, stated with the estimate: 50%; middle value at least 1.2-fold (0.09 log units) from the limit.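

A third substituent at this position now ends at the same ceiling in this assay, so chloro joins hydrogen and nitro there, and compound 4 gives only a limit: the limit of > 50000 nM in this assay, at which 3 of the 4 values shown sit.

Set against methyl, the change from methyl to chloro gives an at least 1.2-fold higher number from compound 2 to compound 4 (0.10 log units; that floor lies within the scatter), so the data show no real gap between these two groups. The steps from compound 1 and from compound 3 to compound 4 join two limits and cannot be read, which means chloro cannot be ranked against hydrogen or nitro.

As far as these compounds go, compound 2 remains the only one of the four with an actual number, and how weak the other three really are stays unknown. From the compounds shown here alone, whether an amine or a methoxy group at this place would give a value clearly inside the range of this assay also stays open.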